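Methyl Added Beside a Chloro Group on a Sulfonyl Aryl Ring

The compounds below may be only part of what the source reports. "The series", "measured", "known", "first", "only" and "open" are said of these compounds alone.

Measured compounds:
- compound 1 `CC1CCN(c2c(S(=O)(=O)c3cccc(Cl)c3)cnc3cc(Cl)ccc23)CC1` — 92%
- compound 2 `CC1CCN(c2c(S(=O)(=O)c3ccc(F)cc3)cnc3ccc(F)cc23)CC1` — 87%
- compound 3 `Cc1ccc2ncc(S(=O)(=O)c3cc(F)cc(F)c3)c(N3CCC(C)CC3)c2c1` — 72%

Of the compounds shown here, three sharing one core have been tested in an assay on isolated protein for displacement of a labelled ligand from metabotropic glutamate receptor 5 (Homo sapiens), with a stated time of 60 min, tested at 1 uM; on this read-out higher numbers stand for more inhibition at the one concentration tested (going by the name of the read-out) and lower numbers for less inhibition. In this assay compound 1 gives 92%, the highest of the three numbers. Compound 2, at 87%, lies within the scatter of compound 1, so the two cannot be told apart. Compound 3, at 72%, sits beyond the scatter below compound 1.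

The next compound, compound 4 `Cc1ccc(S(=O)(=O)c2cnc3cc(Cl)ccc3c2N2CCC(C)CC2)cc1Cl`, is not yet measured. It differs from compound 1 only in the sulfonyl aryl ring: methyl in place of hydrogen on an aromatic carbon. The methyl enters on an aromatic carbon of a six-membered aromatic ring of carbon only, ortho to a chloro group and para to a large group; the ring reads 3-chloro-4-methylphenyl instead of 3-chlorophenyl.

Among the measured compounds shown here, no pair of the measured compounds differs in one place, so no measured step guides this change. Given a single added carbon and no change in donors or acceptors, the step of a number 4 percentage points lower from compound 1 to compound 4 (within the scatter) is expected to stay within the scatter. Compound 4 is therefore estimated at 88%, with a range from 75% to 97%.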

Compound 4, a percentage reported as inhibition, at one concentration (the size of the read-out at that concentration, not a potency): 89%
The estimate for compound 4 lay 1 percentage points below the measured number, and the stated range covers the measured number.
By their numbers in this assay, from the lowest: compound 3; then compounds 2, 4 and 1 (each within the scatter of the next).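

Among the compounds shown here, replacing 3-chlorophenyl with 3-chloro-4-methylphenyl gives the first single-place step in this assay: a number 3 percentage points lower from compound 1 to compound 4 (within the scatter). The added methyl, on an aromatic carbon ortho to a chloro group and para to a large group, therefore leaves no change that this read-out can separate from the usual scatter at the one concentration tested. No measurement is available that bears on why the result falls within the scatter.

The compounds shown leave open whether an ethyl chain, a methoxy group or an amine at the same place would also keep the number within the scatter of compound 1. They also leave open whether a methyl at this place would give a similar result on a sulfonyl aryl ring without the chloro group.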